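Swapping Oxygen for Sulfur in a Sulfonyl-Linked Ring

This account rests on a few compounds, and the source may have more. Where it says the series, first, only, none or still open, it means among the compounds named here.

Three compounds were measured in a functional assay, read by Griess assay, with a stated time of 150 min, tested at 75 ug/mL; on this read-out lower numbers stand for a weaker effect and higher numbers for a stronger effect at the one concentration tested:

Compound 1 `Cc1ccc(C2CNN=C2S(=O)(=O)CC2=NCCS2)cc1` gives 48.6%
Compound 2 `COc1ccc(C2=NOC(c3ccc(C)cc3)C2S(=O)(=O)CC2=NCCO2)cc1` gives 65.9%
Compound 3 `Cc1ccc(C2CNN=C2S(=O)(=O)CC2=NCCO2)cc1` gives 49.7%

Compound 3 and compound 1 share one core and differ by a single change, (a group of 5 heavy atoms (3 carbon, 1 nitrogen, 1 sulfur; one five-membered non-aromatic ring with 2 hetero atoms) in place of a group of 5 heavy atoms (3 carbon, 1 nitrogen, 1 oxygen; one five-membered non-aromatic ring with 2 hetero atoms), on a saturated chain carbon bound to a sulfonyl sulfur). That change made a number 1.1 percentage points lower from compound 3 to compound 1 (within the scatter). Compound 2 rests on a different core; how its core differs from the core of compound 3 is not broken down here, but compound 2 stands highest of the three measured numbers, beyond the scatter from both others.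

Compound 4 `COc1ccc(C2=NOC(c3ccc(C)cc3)C2S(=O)(=O)CC2=NCCS2)cc1` is compound 2 with the same change applied, (a group of 5 heavy atoms (3 carbon, 1 nitrogen, 1 sulfur; one five-membered non-aromatic ring with 2 hetero atoms) in place of a group of 5 heavy atoms (3 carbon, 1 nitrogen, 1 oxygen; one five-membered non-aromatic ring with 2 hetero atoms), on a saturated chain carbon bound to a sulfonyl sulfur). Among the compounds with values here, since the only earlier example of this change, from compound 3 to compound 1, stayed within the scatter, the step from compound 2 to compound 4 is expected to be about a number 0.9 percentage points lower from compound 2 to compound 4 (within the scatter). Within the data shown here, compound 4 is therefore estimated at 65%, most likely between 54% and 76%, with the wider range allowing for the single precedent on another core.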

Compound 4, a percentage reported as activity, at one concentration (the size of the read-out at that concentration, not a potency): 54.1%
For compound 4 the middle estimate is 10.9 percentage points above the measured one; the range from low to high includes it.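

In this assay, placing the sulfur-containing ring on the saturated chain carbon bound to the sulfonyl sulfur, in place of the oxygen-containing ring, gave a number 11.8 percentage points lower from compound 2 to compound 4 (beyond the scatter). Set beside the same change on the other core, this step cannot be told apart from the earlier one: the same change on two cores in this assay, a number 1.1 percentage points lower (within the scatter) from compound 3 to compound 1 and a number 11.8 percentage points lower (beyond the scatter) from compound 2 to compound 4, 10.7 percentage points apart, within the scatter of two such steps The results therefore give no sign that the core alters the effect of this change, but two pairs are too few to show that the effect carries over reliably.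

The compounds shown leave open how the change behaves on a third core. They also leave open what an open-chain amine or a longer carbon chain would give in place of either ring.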